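The compounds below may be only part of what the source reports. "The series", "measured", "known", "first", "only" and "open" are said of these compounds alone.

Compound 1 `COc1ccc(C(=O)Nc2c(F)cccc2F)cc1OC1CCCC1` is measured in an assay on isolated protein for inhibition of phosphodiesterase 4A (Sus scrofa) (on this read-out higher numbers stand for weaker inhibition and lower numbers for stronger inhibition), and gives 70 nM. Among the measured compounds shown here, it stands as the lower of the two numbers so far; its only neighbour is compound 2 `COc1ccc(C(=O)Nc2c(C)cccc2Cl)cc1OC1CCCC1`, which in this assay gives 100 nM, and the step of a 1.4-fold higher number from compound 1 to compound 2 (0.15 log units; within the scatter) lies within the scatter. That step exchanges one substituted aryl group on the amide nitrogen for another and leaves the rest of the shared core untouched.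

Compound 3 `COc1ccc(C(=O)Nc2c(F)cccc2F)cc1` differs from compound 1 in another place entirely: hydrogen in place of cyclopentyloxy on an aromatic carbon. For the measured compounds named here, both measured compounds carry the cyclopentyloxy group, so no measured step bears on its removal; the single step in hand, from compound 1 to compound 2, speaks only to the amide-side aryl group and says nothing about this side of the core. The direction and size of the change therefore cannot be read from the data, and the estimate for compound 3 must be wide. Compound 3 is expected to give about 3000 nM in this assay, a range from 300 nM to 30000 nM, an expected step of a 43-fold higher number from compound 1 to compound 3 (1.63 log units; beyond the scatter).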

Compound 3, half-maximal inhibitory concentration: 37000 nM
Compound 3: middle estimate off by 12-fold (1.09 log units), on the low side; the whole stated range lies below it.
By their numbers in this assay, from the lowest: compounds 1 and 2 (each within the scatter of the next); then compound 3.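

Among the compounds shown here, replacing cyclopentyloxy with hydrogen gives the first measured step on this side of the core, and in this assay it is large: a 530-fold higher number from compound 1 to compound 3 (2.72 log units; beyond the scatter). The only earlier step, a 1.4-fold higher number from compound 1 to compound 2 (0.15 log units; within the scatter), concerned the aryl group on the amide nitrogen and stayed within the scatter, so among the compounds shown, the change in this group moves the number far more than that exchange does. Compound 3 keeps the methoxy group and the 2,6-difluorophenyl group, so these parts alone do not reach the level of inhibition seen with compound 1, and nothing available explains why the step has this size.

With only hydrogen standing in for cyclopentyloxy, the compounds shown leave open how much of the step belongs to the ether oxygen and how much to the five-membered ring of carbon, a question that a hydroxy group, an ethoxy group or a cyclohexyloxy group at the same place would address. They also leave open whether the aryl exchange would stay within the scatter without cyclopentyloxy, as the 2-chloro-6-methylphenyl group appears here only with that group in place.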